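A few compounds are considered here, and "the series" means these few. Any claim that something is new, unique, unknown or untested is made for them only; others in the source may bear on it.

In a functional assay on HCT-116 cells (Homo sapiens) for antiproliferative activity, read by MTT assay, with a stated time of 48 h (a higher number here means a weaker inhibitor, a lower number a stronger inhibitor), compound 1 `COc1cccc(C(=O)Nc2cccc(/C=C/C(=O)c3nc4ccccc4[nH]3)c2)c1` gives 3680 nM. For the measured compounds named here, compound 2 `O=C(/C=C/c1cccc(NS(=O)(=O)c2ccc(Cl)cc2)c1)c1nc2ccccc2[nH]1` gives 1960 nM in this assay, which stands within the scatter of compound 1, and the only known step around it is a 1.9-fold lower number from compound 1 to compound 2 (0.27 log units; within the scatter). Compound 3 `Cc1ccc(S(=O)(=O)Nc2cccc(/C=C/C(=O)c3nc4ccccc4[nH]3)c2)cc1` differs from compound 2 by methyl in place of chloro on an aromatic carbon. Going by the values given here, no measured step bears on this change; the one known step concerns a different part of the molecule. With nothing to point either way, no shift beyond the scatter is expected, and the estimated step is a 1.2-fold higher number from compound 2 to compound 3 (0.09 log units; within the scatter). Compound 3 is therefore expected to give about 2400 nM, in a range from 900 nM to 6500 nM.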

Compound 3, half-maximal inhibitory concentration: 1990 nM
Compound 3: the middle estimate sits 1.2-fold (0.08 log units) above what was measured, and the stated range covers the measured number.
By their numbers in this assay, from the lowest: compounds 2, 3 and 1 (each within the scatter of the next).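

With methyl in place of chloro on this aromatic carbon, para to a large group, this assay gives a 1.0-fold higher number from compound 2 to compound 3 (0.01 log units; within the scatter), so these two groups cannot be told apart here. Replacing the (3-methoxyphenyl)carbonyl with (4-methylphenyl)sulfonyl gives a 1.8-fold lower number from compound 1 to compound 3 (0.27 log units; within the scatter), which again stays within the scatter, as the (4-chlorophenyl)sulfonyl swap did. Nothing available offers a reason for either result. Going by these compounds, it remains open whether an amine or a carboxylic acid on this carbon would shift the number beyond the scatter.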